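Ester variation on the shared core

The compounds below may be only part of what the source reports. "The series", "measured", "known", "first", "only" and "open" are said of these compounds alone.

Three compounds of the shared core have been run in a functional assay on the whole organism with Rattus norvegicus as the target, with a stated time of 4 h, at a dose of 40 mg/kg by the intraperitoneal route; a lower number here means less inhibition, a higher number more inhibition at the dose given (going by the name of the read-out). Compound 1 `[C-]#[N+]Cc1c(C)nc2c(OCc3ccccc3)cccn12` gives 96%. Compound 2 `Cc1nc2c(OCc3ccccc3)cccn2c1CO` gives 99%. Compound 3 `CC(=O)OCc1c(C)nc2c(OCc3ccccc3)cccn12` gives 88%. Compound 3 holds the lowest of the three numbers: the step of a number 8 percentage points lower from compound 1 to compound 3 (within the scatter) lies within the scatter, whereas the step of a number 11 percentage points lower from compound 2 to compound 3 (beyond the scatter) lies beyond it, so compound 3 sits measurably under compound 2 but is not separated from compound 1. The step of a number 3 percentage points higher from compound 1 to compound 2 (within the scatter) is within the scatter.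

Compound 4 `Cc1nc2c(OCc3ccccc3)cccn2c1COC(=O)C(C)(C)C` is yet to be measured in this assay. It differs from compound 3 by tert-butyl in place of methyl on a carbonyl carbon; read one bond further out, acetyl becomes (tert-butyl)carbonyl and acetoxymethyl becomes (((tert-butyl)carbonyl)oxy)methyl. For the measured compounds named here, the only measured step that touches the ester is a number 11 percentage points lower from compound 2 to compound 3 (beyond the scatter), which put acetyl in place of hydrogen on the oxygen and cost a modest amount. Going by the values given here, no measured step alters the carbon group on the carbonyl carbon itself, so there is no direct precedent. With all three measured compounds in a narrow high band, the expectation is that compound 4 stays close, with at most a further modest lowering. The estimated step for compound 4 is a number 4 percentage points lower from compound 3 to compound 4 (within the scatter). Compound 4 is therefore expected at 84%, within 70% to 96%.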

Compound 4, a percentage reported as inhibition, in the whole organism at one dose (the size of the read-out at that dose, not a potency): 48%
For compound 4 the middle estimate is 36 percentage points above the measured one; the measured number lies below the stated range.
By their numbers in this assay, from the lowest: compound 4; then compounds 3, 1 and 2 (each within the scatter of the next, the first and the last beyond it).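

In this assay, for the compounds shown here, the carbon group on the carbonyl carbon of the ester proves decisive: tert-butyl in place of methyl gives a number 40 percentage points lower from compound 3 to compound 4 (beyond the scatter), a large step in a series that had so far stayed in a narrow high band. Esterification alone does not produce a drop of this size, since acetyl on the oxygen gave only a number 11 percentage points lower from compound 2 to compound 3 (beyond the scatter), whereas (tert-butyl)carbonyl on the same oxygen gives a number 51 percentage points lower from compound 2 to compound 4 (beyond the scatter), and the comparison with the group on the saturated chain carbon of compound 1 gives a number 48 percentage points lower from compound 1 to compound 4 (beyond the scatter). Nothing available here explains why this one change lowers the read-out so strongly.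

Still open, from the compounds shown here alone, is whether the fall builds gradually with the carbon group on the carbonyl carbon or appears only with tert-butyl, a question that an ethyl or isopropyl group there would address. Also open, going by these compounds, is whether the ester link itself is needed for the effect of tert-butyl, which the matching amide or a carbamate carrying a dimethylamino group would test, and a reading at one dose and one time cannot separate a loss of potency from a change in the time course.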